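Hydroxyphenyl position on the shared core: cytotoxicity notes

The source may report more compounds than this note shows. Statements on the series, on what has been measured and on what is new or still open speak of the compounds shown alone.

Measured compounds:
- compound 1 `Oc1ccc(-c2cc(-c3cccc(Cl)c3)nc(-c3ccccn3)c2)cc1`: 25400 nM
- compound 2 `Oc1ccc(-c2cc(-c3ccsc3)nc(-c3cccc(Cl)c3)c2)cc1`: 2670 nM
- compound 3 `Oc1cccc(-c2cc(-c3cccnc3)nc(-c3cccc(Cl)c3)c2)c1`: "not determined" (no result reported)

In an ADME assay on HEK293 cells (Homo sapiens) for cytotoxicity, read by CCK-8 assay and cell counting, with a stated time of 2 days (on this read-out higher numbers stand for weaker inhibition and lower numbers for stronger inhibition), compound 1 gives 25400 nM, and compound 2 gives 2670 nM. Within the data shown here, the only step between measured neighbours is a 9.5-fold lower number from compound 1 to compound 2 (0.98 log units; beyond the scatter). In this assay compound 3 is recorded as "not determined" (no result reported), so it stands nowhere on the scale; it serves here only as the structural starting point.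

Compound 4 `Oc1ccc(-c2cc(-c3cccnc3)nc(-c3cccc(Cl)c3)c2)cc1` differs from compound 3 in one place: 4-hydroxyphenyl in place of 3-hydroxyphenyl on an aromatic carbon. Among the measured compounds shown here, no measured step bears on this change. For the measured compounds named here, the one step that exists, a 9.5-fold lower number from compound 1 to compound 2 (0.98 log units; beyond the scatter), moves a different group, so it says nothing about moving the hydroxyl from one position of the ring to the other. What the measured compounds do show is that both of them carry the 4-hydroxyphenyl group that enters in compound 4. In this assay compound 1 gives 25400 nM. In this assay compound 2 gives 2670 nM. Compound 4 also carries a pyridin-3-yl group not present in either of them, so no direction can be assigned.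

Compound 4 is therefore expected to give about 8000 nM in this assay, estimated between 2000 nM and 40000 nM.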

Compound 4, half-maximal inhibitory concentration: 25700 nM
Estimate against measurement, compound 4: 3.2-fold (0.51 log units) below, within the range that was stated.
By their numbers in this assay, from the lowest: compound 2; then compounds 1 and 4 (each within the scatter of the next).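

Compound 4 sets the pyridin-3-yl group against both earlier neighbours in this assay, and replacing thiophen-3-yl with it gives a 9.6-fold higher number from compound 2 to compound 4 (0.98 log units; beyond the scatter), so the reading at this place on the shared core depends on which ring sits there. Replacing pyridin-2-yl with pyridin-3-yl gives a 1.0-fold higher number from compound 1 to compound 4 (0.01 log units; within the scatter), so the two pyridine attachments are not told apart here, and among the three compounds with a number, only the thiophen-3-yl compound stands apart from the others. The step from compound 3 to compound 4 cannot be read, which leaves the change from 3-hydroxyphenyl to 4-hydroxyphenyl without any size or direction, and no supporting data are available to explain the differences that can be read.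

Still open, as far as these compounds go, is how a 3-hydroxyphenyl group reads on this core against the 4-hydroxyphenyl group when the rest of the molecule is held fixed. Also open, from the compounds shown here alone, is whether the lower number stays with thiophen-3-yl alone or extends to a furan-3-yl ring, and how an amine or a carboxylic acid would read in place of the hydroxyl.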